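A few compounds are considered here, and "the series" means these few. Any claim that something is new, unique, unknown or untested is made for them only; others in the source may bear on it.

Measured in a functional assay on MDA-MB-231 cells (Homo sapiens) for antiproliferative activity, read by sulforhodamine B assay, with a stated time of 48 h; a higher number here means a weaker inhibitor of growth, a lower number a stronger inhibitor of growth
- compound 1 `O=C1COc2ccccc2N1CCCn1cc(-c2ccccc2)nn1` gives 4900 nM
- compound 2 `Cc1ccc(-c2cn(CCCN3C(=O)COc4ccccc43)nn2)cc1` gives 1120 nM
- compound 3 `COc1ccc(-c2cn(CCCN3C(=O)COc4ccccc43)nn2)cc1` gives 41500 nM

Compound 3 has the highest number of the three and is the weakest inhibitor of growth here. Its distance from the other two is an 8.5-fold higher number from compound 1 to compound 3 (0.93 log units; beyond the scatter) and a 37-fold higher number from compound 2 to compound 3 (1.57 log units; beyond the scatter).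

The next compound is compound 4 `CCCCCCc1cn(CCCN2C(=O)COc3ccccc32)nn1`, and the change is hexyl in place of 4-methoxyphenyl on an aromatic carbon. In words, hexyl replaces 4-methoxyphenyl on an aromatic carbon of the five-membered ring.

For the measured compounds named here, no measured step removes the aromatic ring, so there is no direct precedent for this swap. The nearest evidence comes from substitution on that ring, where the first methyl change is a 4.4-fold lower number from compound 1 to compound 2 (0.64 log units; beyond the scatter). The methoxy group, which leaves in this change, accounts for the upward steps to compound 3 shown above. Three compounds make a thin basis, but the position of compound 3 at the top of the range points to a lower number in this assay, of modest size and with wide uncertainty.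

The expected step is a 6.9-fold lower number from compound 3 to compound 4 (0.84 log units; beyond the scatter).

The estimate for compound 4 is 6000 nM, with an expected range of 1200 nM to 30000 nM.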

Compound 4, concentration for 50% growth inhibition: 1100 nM
For compound 4 the middle estimate is 5.5-fold (0.74 log units) above the measured one; the measured number lies below the stated range.
By their numbers in this assay, from the lowest: compounds 4 and 2 (each within the scatter of the next); then compound 1; then compound 3.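

In this assay, an aromatic ring at this carbon of the five-membered ring is not required for growth inhibition: with hexyl, which has no ring, the series shows a 4.5-fold lower number from compound 1 to compound 4 (0.65 log units; beyond the scatter), and replacing the 4-methoxyphenyl group gives a 38-fold lower number from compound 3 to compound 4 (1.58 log units; beyond the scatter). Hexyl and 4-methylphenyl cannot be separated in this assay, with a 1.0-fold lower number from compound 2 to compound 4 (0.01 log units; within the scatter), so an open chain and a substituted aromatic ring can reach the same level here, and the high number of compound 3 is specific to the 4-methoxyphenyl group among the four groups compared. No evidence is available to explain why these groups differ.

On these data alone, whether activity at this carbon follows chain length remains open, and a butyl or octyl chain, a branched chain, or a hexyl chain ending in an amine or a carboxylic acid would test how far the result with hexyl extends. As far as these compounds go, it is also open whether the result for compound 3 belongs to the methoxy oxygen or to any larger group at that place on the phenyl ring, a question that 4-hydroxyphenyl and 4-ethylphenyl groups would address.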